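This account rests on a few compounds, and the source may have more. Where it says the series, first, only, none or still open, it means among the compounds named here.

Of the compounds shown here, two with the shared core have been measured so far. In a functional assay on HCT-116 cells (Homo sapiens) for inhibition, read by MTT assay, with a stated time of 72 h (on this read-out lower numbers stand for stronger inhibition and higher numbers for weaker inhibition), compound 1 (`Cc1ccc(CN2CCc3ncn(COCc4ccccc4)c3/C(=C/c3ccccc3)C2=O)cc1`) gives 7940 nM and compound 2 (`O=C1/C(=C\c2ccccc2)c2c(ncn2COCc2ccccc2)CCN1Cc1ccc(-c2ccccc2)cc1`) gives 14000 nM. These two values lie within the scatter of each other, so compound 2 stands level with compound 1 and no ranking can be read from them.

The next compound is compound 3 (`Cc1ccccc1CN1CCc2ncn(COCc3ccccc3)c2/C(=C/c2ccccc2)C1=O`). The change from compound 2 is 2-methylphenyl in place of 4-phenylphenyl on a saturated chain carbon bound to an amide-type nitrogen in a ring. Within the data shown here, only one measured step bears on it: a 1.8-fold higher number from compound 1 to compound 2 (0.25 log units; within the scatter), with phenyl in place of methyl on an aromatic carbon, and this stays within the scatter. Among the measured compounds shown here, no measured compound carries the 2-methylphenyl group, so the evidence is thin. No step beyond the scatter is expected in this assay. The estimated step is a 1.6-fold lower number from compound 2 to compound 3 (0.19 log units; within the scatter). For compound 3 the expected value is 9000 nM, with an estimated range of 3500 nM to 22000 nM.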

Compound 3, half-maximal inhibitory concentration: 24700 nM
Beside the measured number, compound 3's estimate is 2.7-fold (0.44 log units) below it, outside the stated range (above it).
By their numbers in this assay, from the lowest: compounds 1, 2 and 3 (each within the scatter of the next, the first and the last beyond it).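

Among these compounds, on the saturated chain carbon bound to an amide-type nitrogen in a ring, 2-methylphenyl in place of 4-methylphenyl gives the first step beyond the scatter in this assay, with a 3.1-fold higher number from compound 1 to compound 3 (0.49 log units; beyond the scatter), so inhibition here is modestly weaker with the 2-methylphenyl group. By contrast, 2-methylphenyl in place of 4-phenylphenyl gives a 1.8-fold higher number from compound 2 to compound 3 (0.25 log units; within the scatter), so that pair cannot be ordered, and 4-phenylphenyl is not separated from either of the other two groups. No measured evidence bears on the origin of the step between the two methylphenyl groups.

Still open is how 3-methylphenyl or unsubstituted phenyl would sit among these three groups at this position. Also open, as far as these compounds go, is whether an amine or a carboxylic acid on this aromatic ring would give a lower number.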